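This account rests on a few compounds, and the source may have more. Where it says the series, first, only, none or still open, it means among the compounds named here.

Measured compounds:

- Compound 1, `CCCCSC[C@H](NC(C)=O)C(=O)CCl`: 5600 nM
- Compound 2, `CCCCCSC[C@H](NC(C)=O)C(=O)CCl`: 5400 nM
- Compound 3, `CCCCCCCCCCCCCCCSC[C@H](NC(C)=O)C(=O)CCl`: 8600 nM

The three compounds were tested in a functional assay on MOLT-3 cells (Homo sapiens); a higher number here means a weaker inhibitor, a lower number a stronger inhibitor. In this assay compound 1 gives 5600 nM and compound 2 gives 5400 nM. Compound 2 differs from compound 1 by methyl in place of hydrogen on a saturated chain carbon, four bonds along the chain from a sulfur, and that change produced a 1.0-fold lower number from compound 1 to compound 2 (0.02 log units; within the scatter). Compound 3 gives 8600 nM in this assay; it stands apart from compound 1 by a larger portion of the molecule, and the difference between the two cores is not broken down here. Its value sits within the scatter of those of compound 1 and compound 2, so no order among the three can be drawn from these numbers.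

Compound 4, `CCCCCCCCCCCCCCCCSC[C@H](NC(C)=O)C(=O)CCl`, has not yet been measured. It differs from compound 3 by methyl in place of hydrogen on a saturated chain carbon, ten or more bonds along the chain from a sulfur. This is the same kind of change as that from compound 1 to compound 2, though not the same one: the methyl enters at a different point along the chain from a sulfur, as the two differences just given show. For compound 4 the step expected in this assay is a 1.0-fold higher number from compound 3 to compound 4 (0.02 log units; within the scatter), an estimate that rests on compound 1 and compound 2 because a 1.0-fold lower number from compound 1 to compound 2 (0.02 log units; within the scatter) was flat. On that basis compound 4 is expected to give about 9000 nM in this assay, with a likely range from 4000 nM to 20000 nM.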

Compound 4, half-maximal inhibitory concentration: 17300 nM
For compound 4 the middle estimate is 1.9-fold (0.28 log units) below the measured one, within the range that was stated.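

In this assay, methyl in place of hydrogen on a saturated chain carbon, ten or more bonds along the chain from a sulfur, gave a 2.0-fold higher number from compound 3 to compound 4 (0.30 log units; within the scatter), so the new step, like the earlier one, does not stand clear of the usual scatter. Set side by side, the two steps cannot be told apart: the same change on two cores in this assay, a 1.0-fold lower number (0.02 log units; within the scatter) from compound 1 to compound 2 and a 2.0-fold higher number (0.30 log units; within the scatter) from compound 3 to compound 4, 2.1-fold (0.32 log units) apart, within the scatter of two such steps This shows that, across these two pairs, the change carried from the core of compound 1 to the core of compound 3 with no difference these numbers can resolve, but it does not show that the two steps are truly equal, that the change has no effect, or that the same reading would hold on any other core in the series, and the methyl also enters at a different point along the chain in each pair.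

The compounds shown leave open how a chain longer than that of compound 4, a phenyl ring in place of the chain, or a chain bearing an amine or a carboxylic acid would read in this assay. They also leave open whether the same change, made at other points along the chain from a sulfur, would stay within the scatter.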